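The compounds below may be only part of what the source reports. "The series", "measured", "known", "first", "only" and "open" are said of these compounds alone.

Measured so far in an assay (Rattus norvegicus) for inhibition of Fatty-acid amide hydrolase 1 (Homo sapiens); on this read-out higher numbers stand for weaker inhibition and lower numbers for stronger inhibition:
- compound 1 `N#Cc1ccccc1-c1cnc(C(=O)CCCCCCc2ccccc2)o1`: 130 nM
- compound 2 `CN(C)C(=O)c1cnc(C(=O)CCCCCCc2ccccc2)o1`: 2 nM

Among the measured compounds shown here, compound 2 holds the lowest of the two numbers in this assay, and the only other compound, compound 1, sits well apart from it: the single measured step, a 65-fold lower number from compound 1 to compound 2 (1.81 log units; beyond the scatter), exchanges the 2-cyanophenyl group on an aromatic carbon for dimethylcarbamoyl. Compound 3 `O=C(CCCCCCc1ccccc1)c1ncc(C(=O)N2CCSCC2)o1` is not yet measured. It differs from compound 2 in a different place: thiomorpholin-4-yl in place of dimethylamino on a carbonyl carbon. The measured step does not touch this part of the molecule, so nothing measured bears on it directly; only the amine part of the amide is exchanged, while the dimethylcarbamoyl-type amide that set compound 2 apart is kept. For compound 3 a step within the scatter is therefore expected, that is a 1.5-fold higher number from compound 2 to compound 3 (0.18 log units; within the scatter), giving an estimated 3 nM in this assay, with a range from 1 nM to 12 nM.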

Compound 3, inhibition constant: 10 nM
Beside the measured number, compound 3's estimate is 3.3-fold (0.52 log units) below it, within the range that was stated.
By their numbers in this assay, from the lowest: compound 2; then compound 3; then compound 1.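

In this assay, the amine part of the amide on this carbonyl carbon proves able to shift the number: thiomorpholin-4-yl in place of dimethylamino brings a 5.0-fold higher number from compound 2 to compound 3 (0.70 log units; beyond the scatter), a modest step, but one that goes beyond the usual scatter. The amide with the new ring still keeps much of the gain seen over the 2-cyanophenyl group, with a 13-fold lower number from compound 1 to compound 3 (1.11 log units; beyond the scatter). No measurement available here explains why this ring gives a higher number than dimethylamino.

The compounds shown cannot tell whether the change follows from the ring itself or from its sulfur, a question that a piperidine amide and a morpholine amide could help separate. On these data alone, it also remains open how a smaller amine on the same carbonyl carbon, such as methylamine with its amide hydrogen, would compare with dimethylamino.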